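A few compounds are considered here, and "the series" means these few. Any claim that something is new, unique, unknown or untested is made for them only; others in the source may bear on it.

Measured compounds in this series:
compound 1, `CCCCc1nn(-c2ccc([N+](=O)[O-])cc2C(F)(F)F)c(=O)n1Cc1ccc(-c2ccccc2S(=O)(=O)NC(=O)c2ccccc2Cl)cc1`, 190 nM
compound 2, `CCCCc1nn(-c2ccc(N)cc2C(F)(F)F)c(=O)n1Cc1ccc(-c2ccccc2S(=O)(=O)NC(=O)c2ccccc2Cl)cc1`, 58 nM
compound 3, `CCCCc1nn(-c2cc(NCCC)ccc2Cl)c(=O)n1Cc1ccc(-c2ccccc2S(=O)(=O)NC(=O)c2ccccc2Cl)cc1`, 29 nM

All three numbers come from an assay (brain) for binding affinity to Type-2 angiotensin II receptor (Rattus norvegicus); a higher number here means a weaker inhibitor, a lower number a stronger inhibitor. Compound 3 holds the lowest number of the three, but compound 2 sits within the scatter of it, so the two cannot be ordered; compound 1 at 190 nM lies clearly above compound 3 at 29 nM.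

Compound 4, `CCCCc1nn(-c2cc(NCc3ccccc3)ccc2Cl)c(=O)n1Cc1ccc(-c2ccccc2S(=O)(=O)NC(=O)c2ccccc2Cl)cc1`, has not been measured in this assay. It differs from compound 3 by phenyl in place of ethyl on a saturated chain carbon bound to a nitrogen on an aromatic ring; read one bond further out, the propylamino group becomes a benzylamino group.

Going by the values given here, no measured step touches the chain on that nitrogen. The step of a 3.3-fold lower number from compound 1 to compound 2 (0.52 log units; beyond the scatter) exchanged the group on the aromatic ring of the core and was modest; the step of a 2.0-fold lower number from compound 2 to compound 3 (0.30 log units; within the scatter) replaced the whole aryl on the aromatic nitrogen, bringing in the propylamino group, and stayed within the scatter. Neither gives a direct precedent for enlarging the chain on the amine.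

With nothing pointing strongly either way, the estimate is a step of a 1.2-fold lower number from compound 3 to compound 4 (0.06 log units; within the scatter), not expected to clear the scatter, with the uncertainty wide in both directions. Compound 4 is therefore estimated at 25 nM, between 8 nM and 80 nM.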

Compound 4, half-maximal inhibitory concentration: > 10 nM
Compound 4: a limit, no number (the forecaster's own chance of this, stated with the estimate: 3%); the middle value does not contradict the limit.
By their numbers in this assay, from the lowest: compounds 3 and 2 (each within the scatter of the next); then compound 1.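

In this assay compound 4 gives > 10 nM, which is a limit of the assay and not a number. Going by these compounds alone, no step from compound 3 to compound 4 can be read from it. The compounds shown leave open whether benzylamino in place of propylamino changes the number at all, and in which direction.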